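This account rests on a few compounds, and the source may have more. Where it says the series, first, only, none or still open, it means among the compounds named here.

In an ADME assay on L132 cells (Homo sapiens) for cytotoxicity, read by MTT assay, with a stated time of 72 h (on this read-out lower numbers stand for stronger inhibition and higher numbers for weaker inhibition), compound 1 `COc1cc(C2=C(c3cc(C)c(OC)c(C)c3)C(OC(C)=O)CC2=O)cc(OC)c1OC` gives > 100 ug/mL and this is a limit of the assay, not a number. Compound 3 `COc1ccc(OC)c(C2=C(c3cc(OC)c(OC)c(OC)c3)C(=O)CC2O)c1` gives > 100 ug/mL and this too is a limit. Compound 1 therefore stands at the limit of > 100 ug/mL in this assay, at which 2 of the 3 values shown sit, and has no exact position on the scale. Only compound 2 `COc1ccc(C2=C(c3cc(OC)c(OC)c(OC)c3)C(=O)CC2OC(C)=O)cc1NC=O` gives a true number, 2 ug/mL in the same test.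

For the measured compounds named here, the one measured step is an at least 50-fold lower number from compound 1 to compound 2 (1.69 log units; beyond the scatter) and it comes with 3-(formylamino)-4-methoxyphenyl in place of 4-methoxy-3,5-dimethylphenyl on a double-bonded ring carbon. Compound 4 `COc1cc(C2=C(c3cc(C)c(OC)c(C)c3)C(O[SiH2]C(C)(C)C)CC2=O)cc(OC)c1OC` keeps the 4-methoxy-3,5-dimethylphenyl group of compound 1 and changes elsewhere: a group of 5 heavy atoms (4 carbon, 1 silicon; no ring) in place of a group of 3 heavy atoms (2 carbon, 1 oxygen; no ring), on an oxygen on a saturated carbon describes the difference. Going by the values given here, the large step thus concerns another place in the molecule, and no measured step covers an exchange on this oxygen.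

With so little direct evidence, the expectation stays close to compound 1, whose > 100 ug/mL is again only a limit. The expected step is a number no higher from compound 1 to compound 4 (the limit leaves the size open) and no shift beyond the scatter is anticipated, although the range leaves room for a lower number. For compound 4 the estimated value in this assay is 100 ug/mL with an expected range from 15 ug/mL to 300 ug/mL and the assay may well report only a limit.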

Compound 4, half-maximal inhibitory concentration: > 100 ug/mL
Compound 4 was reported as a limit; the forecaster's own chance of this, stated with the estimate: 60%; the middle value lies on the limit itself.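

For the compounds shown here, compound 1 and compound 4 both stand at the same limit of the assay rather than at a number, so no step between them can be read: the limit of > 100 ug/mL in this assay, at which 3 of the 4 values shown sit. The compounds shown leave open whether exchanging the acetyl on this oxygen for the larger silicon-containing group changes the read-out at all.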